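The compounds below may be only part of what the source reports. "The series", "measured", "known", "first", "only" and "open" are said of these compounds alone.

Measured so far in an in vitro functional assay on SH-SY5Y cells for agonist activity at Neuronal acetylcholine receptor; alpha3/beta4 (Homo sapiens), read by FLIPR and calcium flux; a lower number here means that less compound is needed, a higher number that more compound is needed for the effect:

Compound 1 `COc1cncc(C2=CC3CC(C2)CN(C)C3)c1` gives 3640 nM.
Compound 2 `CC(C)Oc1cncc(C2=CC3CNCC(C2)C3)c1` gives 69 nM.
Compound 3 `COc1cncc(C2=CC3CNCC(C2)C3)c1` gives 105 nM.

Compound 2 has the lowest number of the three in this assay, although compound 3 lies within the usual scatter of it, so the two cannot be told apart; compound 1 stands far higher. The measured step between these two is a 1.5-fold higher number from compound 2 to compound 3 (0.18 log units; within the scatter), and it is small.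

Compound 4 `CC(C)Oc1cncc(C2=CC3CC(C2)CN(C)C3)c1` has not yet been measured. It differs from compound 2 by methyl in place of hydrogen on an amine nitrogen in a ring. Within the data shown here, the one measured step that bears on this change runs the other way: a 35-fold lower number from compound 1 to compound 3 (1.54 log units; beyond the scatter), where removing that same methyl from the ring nitrogen brought a large drop in the number. Adding the methyl back, as in compound 4, is therefore expected to raise the number by a comparably large margin. For compound 4 the expected step is a 35-fold higher number from compound 2 to compound 4 (1.54 log units; beyond the scatter), a rise well beyond the scatter. The estimate for compound 4 in this assay is 2400 nM, with a range from 800 nM to 7000 nM.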

Compound 4, half-maximal effective concentration: > 10000 nM
Compound 4: only a limit was reported; the forecaster's own chance of this, stated with the estimate: 5%; middle value at least 4.1-fold (0.61 log units) from the limit.
By their numbers in this assay, from the lowest: compounds 2 and 3 (each within the scatter of the next); then compound 1. At a limit, above all of these: compound 4.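

Methyl in place of hydrogen on the amine nitrogen in a ring gives an at least 140-fold higher number from compound 2 to compound 4 (2.16 log units; beyond the scatter) in this assay, and because the reading for compound 4 is a limit and not a number, the true step may be larger still: the limit of > 10000 nM in this assay, at which 1 of the 4 values shown sits.

So the rise that this methyl brings is not the same on every core, as the two steps differ by more than the scatter: the same change on two cores in this assay, a 35-fold lower number (1.54 log units; beyond the scatter) from compound 1 to compound 3 and an at least 140-fold lower number (2.16 log units; beyond the scatter) from compound 4 to compound 2, at least 4.1-fold (0.62 log units) apart, beyond the scatter of two such steps

The group on the oxygen also matters more once the ring nitrogen carries methyl, since isopropyl in place of methyl gives an at least 2.7-fold higher number from compound 1 to compound 4 (0.43 log units; beyond the scatter), whereas the same swap with hydrogen on that nitrogen leaves compound 2 and compound 3 within the scatter of each other: the same change on two cores in this assay, a 1.5-fold higher number (0.18 log units; within the scatter) from compound 2 to compound 3 and an at least 2.7-fold lower number (0.43 log units; beyond the scatter) from compound 4 to compound 1, at least 4.1-fold (0.62 log units) apart, beyond the scatter of two such steps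

On these data alone, how far compound 4 lies past its limit stays open, so both gaps between steps are known only as minimum sizes. Also open, as far as these compounds go, is whether an ethyl group on the ring nitrogen, or a longer chain or a cyclopropyl group on the oxygen, would follow the same pattern, since these three compound pairs cover only methyl and isopropyl on the oxygen and only hydrogen and methyl on the nitrogen.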